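Chromene carboxamides: fluoromethyl step on the aortic response

The source may hold more compounds than are shown below. What is called first, only, known or untested is meant among the compounds shown, and "the series" means these compounds.

Measured in a functional assay on the whole organism (aorta) with Rattus norvegicus as the target; a lower number here means a smaller maximal response, a higher number a larger maximal response:
compound 1, `CNC(=O)C1=CC(C)(C)Oc2ccc([N+](=O)[O-])cc21`: 61%
compound 2, `CNC(=O)C1=CC(C)(CF)Oc2ccc([N+](=O)[O-])cc21`: 66%
compound 3, `CC1(C)C=C(C(=O)NCCC#N)c2cc([N+](=O)[O-])ccc2O1`: 73.1%

The change from compound 1 to compound 2 is fluoro in place of hydrogen on a saturated chain carbon bound to a saturated ring carbon. It made a number 5 percentage points higher from compound 1 to compound 2 (within the scatter), so the two values stand within the scatter of each other and no direction can be read from them.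

The cores of compound 1 and compound 3 differ by cyanomethyl in place of hydrogen on a saturated chain carbon bound to an amide-type nitrogen. Here the data show a number 12.1 percentage points higher from compound 1 to compound 3 (beyond the scatter), a modest gain that lies beyond the scatter.

Compound 4, `CC1(CF)C=C(C(=O)NCCC#N)c2cc([N+](=O)[O-])ccc2O1`, is not yet measured in this assay. It carries the same change relative to compound 3 that compound 2 carries relative to compound 1: fluoro in place of hydrogen on a saturated chain carbon bound to a saturated ring carbon, at the same place in both pairs, so this is the same change on a different core.

The expectation for compound 4 rests on a single precedent, the pair of compound 1 and compound 2, where the step was a number 5 percentage points higher from compound 1 to compound 2 (within the scatter). A step of similar size is estimated for compound 4, namely a number 4.9 percentage points higher from compound 3 to compound 4 (within the scatter). Compound 4 is therefore expected to give about 78% in this assay, with a likely range from 67% to 89%. With only one prior occurrence of the change, the range is kept wide.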

Compound 4, intrinsic activity: the largest response reached, in percent of the reference agonist's: 71%
Compound 4: the middle estimate sits 7 percentage points above what was measured; the measured number falls inside the stated range.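

In this assay, the methyl to fluoromethyl change gives a number 2.1 percentage points lower from compound 3 to compound 4 (within the scatter), and this step does not differ from its earlier occurrence: the same change on two cores in this assay, a number 5 percentage points higher (within the scatter) from compound 1 to compound 2 and a number 2.1 percentage points lower (within the scatter) from compound 3 to compound 4, 7.1 percentage points apart, within the scatter of two such steps. Among the compounds shown here, the cyanomethyl change gives a number 5 percentage points higher from compound 2 to compound 4 (within the scatter), and it also agrees with its earlier occurrence, although only that earlier step lies beyond the scatter: the same change on two cores in this assay, a number 12.1 percentage points higher (beyond the scatter) from compound 1 to compound 3 and a number 5 percentage points higher (within the scatter) from compound 2 to compound 4, 7.1 percentage points apart, within the scatter of two such steps. Both changes are therefore compatible with carrying over between these cores, but with both fluoromethyl steps inside the scatter, the data do not show that fluoromethyl shifts the maximal response in either direction, and two pairs cannot establish transfer across the wider series.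

Still open, from the compounds shown here alone, is whether trifluoromethyl in place of fluoromethyl would give a step beyond the scatter in this assay. Equally open, going by these compounds, is how the response would follow an amine or a carboxylic acid in place of the nitrile, or a longer chain carrying the nitrile.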